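The compounds below may be only part of what the source reports. "The series", "measured", "known", "first", "only" and "open" are said of these compounds alone.

In a functional assay on RPMI-7951 cells (Homo sapiens) for cytotoxicity (a lower number here means that less compound is needed, a higher number that more compound is needed for the effect), compound 1 `Oc1cc(-c2ccccc2)nc2ccc(Cl)cc12` gives 0.64 ug/mL and compound 2 `Oc1ccc2c(O)cc(-c3ccccc3)nc2c1` gives 0.52 ug/mL. These two values lie within the usual scatter of each other, so compound 2 stands level with compound 1. Compound 3 `Oc1cc(-c2ccccc2)nc2cc(F)ccc12` differs from compound 2 by a single exchange, fluoro in place of hydroxy on an aromatic carbon. For the measured compounds named here, no measured pair shows this change, and no step beyond the scatter is expected in this assay, in either direction. The estimated value for compound 3 is 0.6 ug/mL, within an expected range of 0.2 ug/mL to 1.8 ug/mL. This estimate means an expected 1.2-fold higher number from compound 2 to compound 3 (0.06 log units; within the scatter).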

Compound 3, half-maximal effective concentration: 0.37 ug/mL
Compound 3: middle estimate off by 1.6-fold (0.21 log units), on the high side; the measured number falls inside the stated range.
By their numbers in this assay, from the lowest: compounds 3, 2 and 1 (each within the scatter of the next).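

In this assay the exchange of hydroxy for fluoro gives a 1.4-fold lower number from compound 2 to compound 3 (0.15 log units; within the scatter) and so stays within the scatter. For the compounds shown here, this is the first sign that, at this position, meta to a fused ring and para to a fused ring, the hydrogen-bond donor and acceptor of hydroxy can be lost without a step beyond the scatter. Nothing available explains this result.

From the compounds shown here alone, whether an amine or a methoxy group at this position would also stay level with hydroxy remains open. So does whether this exchange would give the same result on another core.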